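This account rests on a few compounds, and the source may have more. Where it says the series, first, only, none or still open, it means among the compounds named here.

The study concerns three measured compounds and one that is not yet measured. Compound 1 `COc1cc(CNC(=O)CCCC/C=C/C(C)C)ccc1OC(=O)CCC(=O)Oc1ccc(-c2cc(=S)ss2)cc1` and compound 3 `COc1cc(CNC(=O)CCCC/C=C/C(C)C)ccc1OC(=O)CCC(=O)Oc1ccc(C(N)=S)cc1` are built on one core, while compound 2 `COc1cc(CNC(=O)CCCC/C=C/C(C)C)ccc1OCCCCCOc1ccc(C(N)=S)cc1` and compound 4 `COc1cc(CNC(=O)CCCC/C=C/C(C)C)ccc1OCCCCCOc1ccc(-c2cc(=S)ss2)cc1` are built on another; the difference between the two cores is not broken down here. Compound 1 differs from compound 3 by a group of 6 heavy atoms (3 carbon, 3 sulfur; one five-membered aromatic ring with 2 hetero atoms) in place of a group of 3 heavy atoms (1 carbon, 1 nitrogen, 1 sulfur; no ring), on an aromatic carbon. In a functional assay on MCF7 cells (Homo sapiens) for antiproliferative activity, read by MTT assay, with a stated time of 48 h (a lower number here means a stronger inhibitor, a higher number a weaker inhibitor), compound 1 gives 2120 nM. For compound 3 in this assay the value > 50000 nM is a limit of the assay rather than a number. The measured step is therefore an at least 23-fold lower number from compound 3 to compound 1 (1.37 log units; beyond the scatter), and its size rests on (the limit of > 50000 nM in this assay, at which 1 of the 3 values shown sits). In this assay compound 2 gives 17200 nM, a higher number than compound 1 gives. Among the compounds with values here, compound 4 differs from compound 2 by a group of 6 heavy atoms (3 carbon, 3 sulfur; one five-membered aromatic ring with 2 hetero atoms) in place of a group of 3 heavy atoms (1 carbon, 1 nitrogen, 1 sulfur; no ring), on an aromatic carbon, which is the same change, at the same place, as the one that separates compound 3 from compound 1. Within the data shown here, since only one measured example of this change exists, and that example is anchored on a limit, the expectation for compound 4 carries wide bounds. On the strength of the step of an at least 23-fold lower number from compound 3 to compound 1 (1.37 log units; beyond the scatter), the step expected in this assay is a 19-fold lower number from compound 2 to compound 4 (1.28 log units; beyond the scatter). Compound 4 is thus expected to give a value near 900 nM in this assay. The expected range for compound 4 runs from 250 nM to 4000 nM.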

Compound 4, half-maximal inhibitory concentration: > 50000 nM
Compound 4: a limit, no number; the forecaster's own chance of this, stated with the estimate: 3%; middle value at least 55-fold (1.74 log units) away from the limit.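

In this assay compound 4 gives > 50000 nM, which is a limit of the assay and not a number. On the core of compound 2 the change therefore comes with an at least 2.9-fold higher number from compound 2 to compound 4 (0.46 log units; beyond the scatter), so the result on the core of compound 3 does not carry over to this second core, and the two steps run in opposite directions: the same change on two cores in this assay, an at least 23-fold lower number (1.37 log units; beyond the scatter) from compound 3 to compound 1 and an at least 2.9-fold higher number (0.46 log units; beyond the scatter) from compound 2 to compound 4, at least 68-fold (1.83 log units) apart, beyond the scatter of two such steps. What this does not show is the true size of either step, since each rests on a limit, nor can a single pair on each core tell which difference between the two cores decides the outcome: the limit of > 50000 nM in this assay, at which 2 of the 4 values shown sit.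

The compounds shown leave open how the same change would behave on a core with an amide or a longer chain as the link, which would help show whether the reversal follows the link in general or only these two cores. Also open, as far as these compounds go, is whether another group on the same aromatic carbon, such as a carboxylic acid or an amine, would give a number rather than a limit in this assay on the core of compound 2.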